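Swapping the halogen on the phenyl ring of compound 1

The compounds below may be only part of what the source reports. "The series", "measured", "known", "first", "only" and "open" are said of these compounds alone.

Compound 1, `COc1cc(C(=O)c2sc(-c3ccc(I)cc3)cc2N)cc(OC)c1OC`, is the weakest of three measured compounds in a functional assay on MOLT-4 cells (Homo sapiens) for antiproliferative activity (on this read-out higher numbers stand for weaker inhibition and lower numbers for stronger inhibition), where compound 1 gives 190 nM. Compound 2, `COc1cc(C(=O)c2sc(-c3ccncc3)cc2N)cc(OC)c1OC`, gives 88 nM in this assay, and compound 3, `COc1cc(C(=O)c2sc(-c3ccsc3)cc2N)cc(OC)c1OC`, gives 8.8 nM. The measured steps, a 2.2-fold lower number from compound 1 to compound 2 (0.33 log units; beyond the scatter) and a 22-fold lower number from compound 1 to compound 3 (1.33 log units; beyond the scatter), each exchange the whole ring attached to the shared core, and a 10-fold lower number from compound 2 to compound 3 (1.00 log units; beyond the scatter) does the same. Compound 4, `COc1cc(C(=O)c2sc(-c3ccc(F)cc3)cc2N)cc(OC)c1OC`, differs from compound 1 only by fluoro in place of iodo on an aromatic carbon. Within the data shown here, no measured step exchanges one halogen for another on the same six-membered ring, so none of the steps bears directly on this change; the measured steps only show that the identity of the attached ring can move the number a great deal. Without a comparable step, compound 4 is expected to sit near compound 1, with the expected step being a 1.3-fold lower number from compound 1 to compound 4 (0.10 log units; within the scatter). The estimate for compound 4 is therefore 150 nM, in the range 40 nM to 600 nM.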

Compound 4, half-maximal inhibitory concentration: 12 nM
Beside the measured number, compound 4's estimate is 13-fold (1.10 log units) above it; measured number below the stated range.
By their numbers in this assay, from the lowest: compounds 3 and 4 (each within the scatter of the next); then compound 2; then compound 1.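

Changing a single atom on the phenyl ring, with the ring itself kept, is enough to produce a large shift in this assay: a 16-fold lower number from compound 1 to compound 4 (1.20 log units; beyond the scatter). The 4-fluorophenyl group also shows no real difference from thiophen-3-yl, a 1.4-fold higher number from compound 3 to compound 4 (0.13 log units; within the scatter), and it gives a clearly lower number than pyridin-4-yl, a 7.3-fold lower number from compound 2 to compound 4 (0.87 log units; beyond the scatter), so the high number of compound 1 goes with its iodo group and not with the phenyl ring as such. The data offer no explanation for this gap between fluoro and iodo.

Two halogens cannot show whether the number rises steadily from fluoro to iodo, a question that chloro and bromo at this place would address. Also open, as far as these compounds go, is how groups other than halogens, such as methoxy or an amine, would behave there.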